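This account rests on a few compounds, and the source may have more. Where it says the series, first, only, none or still open, it means among the compounds named here.

Measured so far in a functional assay on the whole organism with Mus musculus as the target; a higher number here means that more compound is needed for the effect, a lower number that less compound is needed:
- Compound 1 `COc1cc2c(cc1OC)C(c1cccc(N)c1)=NN=C(S)C2`: 18.8 umol/kg
- Compound 2 `COc1cc2c(cc1OC)C(c1ccc(Br)cc1)=NNC(=O)C2`: 110 umol/kg
- Compound 3 `COc1cc2c(cc1OC)C(c1ccc([N+](=O)[O-])cc1)=NNC(=O)C2`: > 120 umol/kg

Compound 3 has no exact number, only a limit: the limit of > 120 umol/kg in this assay, at which 1 of the 3 values shown sits.

Compound 4 `COc1cc2c(cc1OC)C(c1ccc(Cl)cc1)=NNC(=O)C2` keeps the core of compound 3 and changes one group, with chloro in place of nitro on an aromatic carbon, para to a large group (chloro in place of nitro on an aromatic carbon).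

Going by the values given here, one measured step bears on this change. It concerns the same place on the same core: bromo gives way to nitro, an at least 1.0-fold higher number from compound 2 to compound 3 (0.03 log units; that floor lies within the scatter). As far as these compounds go, that step stays within the scatter, although it rests on just one pair and its true size remains open. Compound 1 differs from compound 3 in more than one place, so it offers no direct guide.

Compound 2 is the nearest measured guide, with bromo where compound 4 has chloro, and compound 2 gives 110 umol/kg. Among the compounds with values here, no step clearly beyond the scatter is therefore expected in this assay. The expected step, estimated against a limit, is an at least 1.2-fold lower number from compound 3 to compound 4 (0.07 log units; that floor lies within the scatter). For compound 4 the estimated value is 100 umol/kg, with an expected range of 45 umol/kg to 200 umol/kg.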

Compound 4, dose for half-maximal effect: 102 umol/kg
The estimate for compound 4 lay 1.0-fold (0.01 log units) below the measured number; the measured number falls inside the stated range.
By their numbers in this assay, from the lowest: compound 1; then compounds 4 and 2 (each within the scatter of the next). At a limit, above all of these: compound 3.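

In this assay, going by these compounds alone, the step of a 1.1-fold lower number from compound 2 to compound 4 (0.03 log units; within the scatter) gives the first direct comparison of two halogens on this aromatic carbon, para to a large group, and bromo and chloro cannot be told apart here. The step away from nitro, an at least 1.1-fold lower number from compound 3 to compound 4 (0.07 log units; that floor lies within the scatter), is only a floor, and it does not show that chloro and nitro truly differ at this place. Compound 3 remains a limit and not a number: the limit of > 120 umol/kg in this assay, at which 1 of the 4 values shown sits.

The compounds shown leave open whether an amine, a methoxy group or a carboxylic acid at this same place on the shared core would move the number beyond the scatter, or whether all groups here give similar results. As far as these compounds go, compound 1 gives 18.8 umol/kg but differs from these compounds in more than one place, and which of those differences goes with its value stays open.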